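A few compounds are considered here, and "the series" means these few. Any claim that something is new, unique, unknown or untested is made for them only; others in the source may bear on it.

Three compounds sharing one core, each carrying a different group on the amide nitrogen of a side chain, have been tested in a functional assay on HOP-62 cells (Homo sapiens) for cytotoxicity, read by sulforhodamine B assay, with a stated time of 48 h; a higher number here means a weaker inhibitor of growth, a lower number a stronger inhibitor of growth. Compound 1 `CCCCC1=NC2(CCCC2)C(=O)N1C(=O)COc1ccc(/C=C2/SC(=O)NC2=O)cc1` reaches only the limit of the assay, giving < 100000 nM. Compound 3 `O=C1NC(=O)/C(=C\c2ccc(OCC(=O)N3C(=O)c4ccccc4S3(=O)=O)cc2)S1` likewise gives a limit, < 100000 nM. Compound 2 `O=C(COc1ccc(/C=C2\SC(=O)NC2=O)cc1)Nc1ncc([N+](=O)[O-])s1` also gives a limit in this assay, namely < 100000 nM. So compound 2 stands where every measured compound stands: at the limit of < 100000 nM in this assay, at which 3 of the 3 values shown sit, and no number separates it from the others.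

Compound 4 `Cc1cc(NC(=O)COc2ccc(/C=C3\SC(=O)NC3=O)cc2)no1` is the next compound to be measured. It differs from compound 2 in one place: 5-methyl-1,2-oxazol-3-yl in place of 5-nitro-1,3-thiazol-2-yl on an amide-type nitrogen. Among the compounds with values here, no step between two measured compounds is available to show what such a change does, and all three known results are limits rather than numbers. The expectation for the step from compound 2 to compound 4 is therefore none beyond the scatter, expressed as a step that the limit leaves unreadable from compound 2 to compound 4. For compound 4 the estimated result in this assay is 30000 nM, expected to lie between 3000 nM and 100000 nM.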

Compound 4, concentration for total growth inhibition: < 100000 nM
Compound 4 was reported as a limit (the forecaster's own chance of this, stated with the estimate: 70%); the middle value lies beyond the limit too.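

No step can be read from compound 2 to compound 4, since replacing 5-nitro-1,3-thiazol-2-yl with 5-methyl-1,2-oxazol-3-yl leaves both results as limits, not numbers: the limit of < 100000 nM in this assay, at which 4 of the 4 values shown sit. The compounds shown leave open how strongly each inhibits growth and whether the group on the amide nitrogen matters.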